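The compounds below may be only part of what the source reports. "The series", "measured", "known", "first", "only" and "open" are said of these compounds alone.

Going by the values given here, compound 2 `COc1cccc(-c2cc(C(=O)Nc3ccc(Oc4ccnc5cc(OCCCN6CCCCC6)c(OC)cc45)c(F)c3)c3ccccc3n2)c1` gives 1740 nM in a functional assay on HT-29 cells (Homo sapiens) for cytotoxicity, read by MTT assay, with a stated time of 72 h (a lower number here means a stronger inhibitor, a higher number a weaker inhibitor), the higher of the two numbers measured so far, while compound 1 `COc1ccc(-c2cc(C(=O)Nc3ccc(Oc4ccnc5cc(OCCCN6CCCCC6)c(OC)cc45)c(F)c3)c3ccccc3n2)cc1` gives 690 nM. Compound 3 `COc1cc2c(Oc3ccc(NC(=O)c4cc(-c5ccc(F)cc5)nc5ccccc45)cc3F)ccnc2cc1OCCCN1CCCCC1` has not been tested and differs from compound 2 by 4-fluorophenyl in place of 3-methoxyphenyl on an aromatic carbon. Among the compounds with values here, the one measured step that bears on this is a 2.5-fold higher number from compound 1 to compound 2 (0.40 log units; beyond the scatter), which exchanged 4-methoxyphenyl for 3-methoxyphenyl. Putting a 4-substituted phenyl back in place of the 3-substituted one is expected to roughly reverse that step, giving a lower number. The estimate for compound 3 is 800 nM, with a range of 300 nM to 2500 nM, a step of a 2.2-fold lower number from compound 2 to compound 3 (0.34 log units; beyond the scatter).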

Compound 3, half-maximal inhibitory concentration: 130 nM
Beside the measured number, compound 3's estimate is 6.2-fold (0.79 log units) above it, outside the stated range (below it).
By their numbers in this assay, from the lowest: compound 3; then compound 1; then compound 2.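

Going by these compounds alone, at this position, on the carbon next to the ring nitrogen, the earlier compounds showed only a methoxy group moving around the phenyl ring, whereas in this assay the change to 4-fluorophenyl gives a 13-fold lower number from compound 2 to compound 3 (1.13 log units; beyond the scatter). With the substituent kept in the 4-position, fluoro in place of methoxy still gives a 5.3-fold lower number from compound 1 to compound 3 (0.72 log units; beyond the scatter), so the substituent's identity matters here as well as its place. Nothing shown gives a reason for this gain.

Still open, going by these compounds, is how 3-fluorophenyl, 4-chlorophenyl or plain phenyl would compare with these groups in this assay.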